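Swapping Methyl for Methoxy on a Shared Core

The compounds below may be only part of what the source reports. "The series", "measured", "known", "first", "only" and "open" are said of these compounds alone.

Of the compounds shown here, three built on one shared core have been measured in a physicochemical assay for lipophilicity; a higher number here means a more lipophilic compound, a lower number a more polar compound. Compound 1 `Clc1ccc(C2=NC(c3ccccc3)CO2)c(Cl)c1` gives 4.4, compound 2 `Ic1ccccc1C1=NC(c2ccccc2)CO1` gives 3.86, and compound 3 `Cc1cccc(C2=NC(c3ccccc3)CO2)c1` gives 4.11. The gaps separating compound 3 from compound 1 and from compound 2 both fall within the usual scatter of this kind of measurement, so the three numbers cannot be told apart. Compound 4 `COc1cccc(C2=NC(c3ccccc3)CO2)c1` has not yet been measured in this assay; it differs from compound 3 in one place: methoxy in place of methyl on an aromatic carbon. Among the compounds with values here, no measured pair shows this exact change, so the expectation rests on the change alone: a step downward, beyond the scatter, is expected a number 0.56 log units lower from compound 3 to compound 4 (beyond the scatter). Compound 4 is estimated at 3.55, within a range from 3.2 to 3.9.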

Compound 4, partition coefficient: 3.77
Estimate against measurement, compound 4: 0.22 log units below; low and high end bracket the measured number.
By their numbers in this assay, from the lowest: compounds 4, 2, 3 and 1 (each within the scatter of the next, the first and the last beyond it).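

The earlier compounds shown here offered no pair differing in one place, so none could show what a single swap does. In this assay, methoxy in place of methyl on an aromatic carbon, meta to a large group, gives a number 0.34 log units lower from compound 3 to compound 4 (beyond the scatter) and so counts as a modest but real step. This is one pair, so it describes this place on the shared core only.

From the compounds shown here alone, whether an amine, a carboxylic acid or a longer chain at this same place would shift the number differently stays open. Nothing shown accounts for the direction or size of the step.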